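A few compounds are considered here, and "the series" means these few. Any claim that something is new, unique, unknown or untested is made for them only; others in the source may bear on it.

Compound 1 `Fc1ccc(C2CC(c3ccc(Cl)s3)=NN2c2nc(-c3ccc(C(F)(F)F)cc3)cs2)cc1`: in a functional assay on A549 cells (Homo sapiens) for antiproliferative activity, read by XTT assay, with a stated time of 24 h (a higher number here means a weaker inhibitor, a lower number a stronger inhibitor), compound 1 gives > 500 ug/mL, a limit of the assay rather than a number.
Compound 2 `Cc1ccc(C2=NN(c3nc(-c4ccccc4)cs3)C(c3ccc(F)cc3)C2)s1`: compound 2 gives > 500 ug/mL, also a limit.
Compound 3 `Cc1ccc(C2=NN(c3nc(-c4ccc(C(F)(F)F)cc4)cs3)C(c3ccc(F)cc3)C2)s1`: compound 3 gives > 500 ug/mL, also a limit.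

For the measured compounds named here, compound 1 thus stands at the limit of > 500 ug/mL in this assay, at which 3 of the 3 values shown sit, and no measured compound gives a readable number. Compound 4 `Fc1ccc(-c2csc(N3N=C(c4ccc(Cl)s4)CC3c3ccc(F)cc3)n2)cc1` differs from compound 1 in one place: fluoro in place of trifluoromethyl on an aromatic carbon. The measured steps that bear on this are a step that the two limits leave unreadable from compound 1 to compound 3 and a step that the two limits leave unreadable from compound 2 to compound 3; both sit between limits, so their size cannot be read. With every shown value at the limit, no step beyond the scatter can be foreseen in this assay , in either direction. Compound 4 is therefore expected to give about 500 ug/mL, between 200 ug/mL and 1000 ug/mL, most likely again only as a limit. The step from compound 1 to compound 4 is expected to be a number no higher from compound 1 to compound 4 (the limit leaves the size open).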

Compound 4, half-maximal inhibitory concentration: > 500 ug/mL
Compound 4 ended at the assay's limit; the forecaster's own chance of this, stated with the estimate: 85%; the middle value lies on the limit itself.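

In this assay compound 4 gives > 500 ug/mL, again a limit of the assay, so the step from compound 1 to compound 4 cannot be read. The compounds shown leave open how strongly any of them acts on these cells, and whether 4-(trifluoromethyl)phenyl to 4-fluorophenyl changes anything: the limit of > 500 ug/mL in this assay, at which 4 of the 4 values shown sit.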